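The source may hold more compounds than are shown below. What is called first, only, known or untested is meant among the compounds shown, and "the series" means these compounds.

Compound 1 `COc1cc(-c2nn(-c3cccc(NC(=O)Nc4ccc(Cl)c(Cl)c4)c3)cc2-c2ccncc2)ccc1Cl`: 810 nM in a functional assay on KM12 cells (Homo sapiens) for inhibition, read by sulforhodamine B assay, with a stated time of 48 h; a higher number here means a weaker inhibitor, a lower number a stronger inhibitor
Compound 2 `COc1cc(-c2nn(-c3cccc(NC(=O)Nc4cccc(C(F)(F)F)c4)c3)cc2-c2ccncc2)ccc1Cl`: 570 nM in this assay

Of these two measured compounds, compound 2 carries the lower number, but the gap to compound 1 is the step of a 1.4-fold lower number from compound 1 to compound 2 (0.15 log units; within the scatter), which stays within the scatter of repeated measurements, so the two cannot be told apart on the numbers shown.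

Compound 3 `COc1cc(-c2nn(-c3cccc(NC(=O)Nc4ccc(Cl)c(C(F)(F)F)c4)c3)cc2-c2ccncc2)ccc1Cl` has not yet been measured. It differs from compound 2 in one place: chloro in place of hydrogen on an aromatic carbon. Among the compounds with values here, only one measured step bears on this kind of change, the step from compound 1 to compound 2, in which the aryl group on the urea nitrogen was exchanged and the number moved by a 1.4-fold lower number from compound 1 to compound 2 (0.15 log units; within the scatter), within the scatter. Since exchanging the whole aryl group hardly moved the number, adding a single chloro to that group is expected to move it little as well, with at most a slight shift toward a lower number.

The expected step for compound 3 is therefore a 1.3-fold lower number from compound 2 to compound 3 (0.10 log units; within the scatter), and compound 3 is estimated at 450 nM in this assay, within a range from 200 nM to 1100 nM.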

Compound 3, half-maximal inhibitory concentration: 1060 nM
Estimate against measurement, compound 3: 2.4-fold (0.37 log units) below; low and high end bracket the measured number.
By their numbers in this assay, from the lowest: compounds 2, 1 and 3 (each within the scatter of the next).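

Within the data shown here, compound 3 is the first case here in which a single atom on this aryl ring changes while the rest of the molecule stays fixed: a chloro replaces hydrogen on the carbon ortho to the trifluoromethyl group and para to a large group. In this assay, that addition gives a 1.9-fold higher number from compound 2 to compound 3 (0.27 log units; within the scatter), so the numbers do not separate the chloro compound from its hydrogen counterpart, although this step is larger than the one seen earlier. The reverse view of the same ring, keeping that chloro and placing trifluoromethyl in place of the other chloro, gives a 1.3-fold higher number from compound 1 to compound 3 (0.12 log units; within the scatter), so the 3,4-dichlorophenyl, 3-(trifluoromethyl)phenyl and 4-chloro-3-(trifluoromethyl)phenyl forms of the urea cannot be told apart in this assay.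

Still open, going by these compounds, is whether this carbon stays as undemanding with something other than hydrogen or chloro on it, such as an amine, a carboxylic acid or a longer chain, any of which could reveal a real difference. Nothing given here accounts for the small differences among these three compounds.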